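A Methyl in Place of Chloro in Compound 2

This account rests on a few compounds, and the source may have more. Where it says the series, first, only, none or still open, it means among the compounds named here.

Among the compounds with values here, in an ADME assay on MT4 cells (Homo sapiens) for cytotoxicity, read by MTT assay (on this read-out lower numbers stand for higher toxicity in this test and higher numbers for lower toxicity in this test), only two compounds have numbers so far. Compound 1 (`Cc1ccc(N(C(=O)c2ccccc2[N+](=O)[O-])C(=S)OCCN2C(=O)c3ccccc3C2=O)cc1`) gives 100000 nM. Compound 2 (`O=C1c2ccccc2C(=O)N1CCOC(=S)N(C(=O)c1c(F)cccc1F)c1ccc(Cl)cc1`) gives 39000 nM, the lower of the two numbers, and its gap to compound 1 lies beyond the scatter. These two compounds differ in more than one place, so their gap cannot be assigned to any single group.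

Compound 3 (`Cc1ccc(N(C(=O)c2c(F)cccc2F)C(=S)OCCN2C(=O)c3ccccc3C2=O)cc1`) is compound 2 with one change: methyl in place of chloro on an aromatic carbon. This puts methyl in place of chloro on an aromatic carbon, turning 4-chlorophenyl into 4-methylphenyl. Within the data shown here, no measured pair shows this change on its own. Among the measured compounds shown here, the only guide is compound 1, which also carries 4-methylphenyl and stands at 100000 nM, so the expectation leans weakly upward. The expected change is a small rise, a 1.4-fold higher number from compound 2 to compound 3 (0.15 log units; within the scatter), that stays within the scatter. Compound 3 is estimated at 55000 nM, with an expected range from 25000 nM to 100000 nM.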

Compound 3, half-maximal cytotoxic concentration: 65000 nM
For compound 3 the middle estimate is 1.2-fold (0.07 log units) below the measured one, and the stated range covers the measured number.
By their numbers in this assay, from the lowest: compounds 2, 3 and 1 (each within the scatter of the next, the first and the last beyond it).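

In this assay, within the data shown here, compounds 2 and 3 form the first pair that isolates this change, and a 1.7-fold higher number from compound 2 to compound 3 (0.22 log units; within the scatter) shows that 4-methylphenyl and 4-chlorophenyl cannot be told apart at this position, para to a large group. Compound 3 also connects the two earlier compounds, which differ in more than one place: 2,6-difluorophenyl in place of 2-nitrophenyl on a carbonyl carbon gives a 1.5-fold lower number from compound 1 to compound 3 (0.19 log units; within the scatter), so the difference between compounds 1 and 2, which lies beyond the scatter, now divides into two single changes, each within the scatter on its own. Nothing available here accounts for the size of either step.

As far as these compounds go, it remains open whether the two single changes would give similar steps in another setting, for example whether methyl in place of chloro would read the same with 2-nitrophenyl on the carbonyl carbon. From the compounds shown here alone, it is also open whether a group of a different kind on this aromatic carbon, such as an amine, a carboxylic acid or a methoxy group, would produce a step beyond the scatter.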